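A few compounds are considered here, and "the series" means these few. Any claim that something is new, unique, unknown or untested is made for them only; others in the source may bear on it.

Compound 1 `NC[C@@H]1C[C@@]1(C(=O)N1C=CCCC1)c1ccsc1` stands at a limit in an assay on HEK293 cells for inhibition of sodium-dependent dopamine transporter (Homo sapiens) (on this read-out higher numbers stand for weaker inhibition and lower numbers for stronger inhibition), where compound 1 gives > 10000 nM. Compound 2 `C=CCN(C)C(=O)[C@@]1(c2ccsc2)C[C@H]1CN` likewise stands at a limit in this assay, where compound 2 gives > 10000 nM. The step that the two limits leave unreadable from compound 1 to compound 2 cannot be read, as both values rest at the limit of > 10000 nM in this assay, at which 2 of the 2 values shown sit. Compound 3 `C=C(F)CN(C)C(=O)[C@@]1(c2ccsc2)C[C@H]1CN` differs from compound 2 by fluoro in place of hydrogen on a double-bonded chain carbon bound to a saturated chain carbon. Going by the values given here, no measured step bears on this change, and compound 2 itself offers only a limit, so neither size nor direction can be drawn from the data. The step expected a step that the limit leaves unreadable from compound 2 to compound 3 is therefore of no readable size. The estimate for compound 3 in this assay is 15000 nM, between 3000 nM and 60000 nM.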

Compound 3, half-maximal inhibitory concentration: > 10000 nM
Compound 3 gave a limit, no number; the forecaster's own chance of this, stated with the estimate: 85%; the middle value is on the limit's open side.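

In this assay compound 3 gives > 10000 nM as a limit, not a number. Going by these compounds alone, no step among compound 1, compound 2 and compound 3 can be read: the limit of > 10000 nM in this assay, at which 3 of the 3 values shown sit. Going by these compounds, how strongly any of the three inhibits, and what fluoro in place of hydrogen changes, stays open.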